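Piperazine for piperidine on a trifluoromethoxy core

This account rests on a few compounds, and the source may have more. Where it says the series, first, only, none or still open, it means among the compounds named here.

Compound 1 `COc1cc2c(Oc3ccc(NC(=O)c4nn(-c5ccccc5C)c(=O)cc4C)cc3F)ccnc2cc1OCCCN1CCC(C)CC1` and compound 2 `COc1cc2c(Oc3ccc(NC(=O)c4nn(-c5ccccc5C)c(=O)cc4C)cc3F)ccnc2cc1OCCCN1CCN(C)CC1` share one core; compound 3 `COc1cc2c(Oc3ccc(NC(=O)c4nn(-c5ccccc5OC(F)(F)F)c(=O)cc4C)cc3F)ccnc2cc1OCCCN1CCC(C)CC1` and compound 4 `COc1cc2c(Oc3ccc(NC(=O)c4nn(-c5ccccc5OC(F)(F)F)c(=O)cc4C)cc3F)ccnc2cc1OCCCN1CCN(C)CC1` share another. The two cores differ by trifluoromethoxy in place of methyl on an aromatic carbon, a change that gave an 18-fold lower number from compound 1 to compound 3 (1.27 log units; beyond the scatter). In a functional assay on MKN-45 cells (Homo sapiens) for inhibition, read by MTT assay, with a stated time of 72 h (a higher number here means a weaker inhibitor, a lower number a stronger inhibitor), compound 1 gives 1290 nM and compound 2 gives 1630 nM; the change between them is 4-methylpiperazin-1-yl in place of 4-methylpiperidin-1-yl on a saturated chain carbon, three bonds along the chain from an oxygen on an aromatic ring, and its step was a 1.3-fold higher number from compound 1 to compound 2 (0.10 log units; within the scatter). Compound 3 gives 70 nM in this assay, the lowest of the three numbers. The same change, (4-methylpiperazin-1-yl in place of 4-methylpiperidin-1-yl on a saturated chain carbon, three bonds along the chain from an oxygen on an aromatic ring), at the same place, carries compound 3 to compound 4. Since this change between compound 1 and compound 2 gave only a 1.3-fold higher number from compound 1 to compound 2 (0.10 log units; within the scatter), a step of similar size, a 1.3-fold higher number from compound 3 to compound 4 (0.11 log units; within the scatter), is expected from compound 3 to compound 4. Compound 4 is therefore estimated at 90 nM in this assay, with a likely span from 40 nM to 200 nM.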

Compound 4, half-maximal inhibitory concentration: 100 nM
Compound 4: middle estimate off by 1.1-fold (0.05 log units), on the low side; measured number inside the range.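

Moving 4-methylpiperazin-1-yl in place of 4-methylpiperidin-1-yl onto the trifluoromethoxy core gave a 1.4-fold higher number from compound 3 to compound 4 (0.15 log units; within the scatter), and trifluoromethoxy in place of methyl, with the 4-methylpiperazin-1-yl group present, gave a 16-fold lower number from compound 2 to compound 4 (1.21 log units; beyond the scatter). The chain-end change carried over between the two cores: the same change on two cores in this assay, a 1.3-fold higher number (0.10 log units; within the scatter) from compound 1 to compound 2 and a 1.4-fold higher number (0.15 log units; within the scatter) from compound 3 to compound 4, 1.1-fold (0.05 log units) apart, within the scatter of two such steps. The aromatic change also kept its size, but this rests on a single pair of cores in this assay and shows neither how far the agreement extends to other cores nor why it arises: the same change on two cores in this assay, an 18-fold lower number (1.27 log units; beyond the scatter) from compound 1 to compound 3 and a 16-fold lower number (1.21 log units; beyond the scatter) from compound 2 to compound 4, 1.1-fold (0.05 log units) apart, within the scatter of two such steps.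

Still open, as far as these compounds go, is whether a morpholine or a dimethylamine at the chain end would behave the same way. Also open, from the compounds shown here alone, are a chain longer than propyl and a chlorine or a methoxy group in place of trifluoromethoxy.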